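The source may report more compounds than this note shows. Statements on the series, on what has been measured and on what is new or still open speak of the compounds shown alone.

Of the compounds shown here, three have numbers so far. Compound 1 `O=C(/C=C/c1cccc(Cl)c1Cl)Nc1cc2c(Nc3ccc(F)c(Cl)c3)ncnc2cc1O[C@H]1CCOC1` carries the 2,3-dichlorophenyl on the double-bonded chain; in a functional assay on MCF7 cells (Homo sapiens) for cytotoxicity, read by MTT assay, with a stated time of 72 h (a higher number here means a weaker inhibitor, a lower number a stronger inhibitor), compound 1 gives 30100 nM. Compound 2 `O=C(/C=C/c1ccc(Br)cc1)Nc1cc2c(Nc3ccc(F)c(Cl)c3)ncnc2cc1O[C@H]1CCOC1` carries the 4-bromophenyl in its place, and in this assay compound 2 gives 32400 nM. Compound 3 `COc1cc2ncnc(Nc3ccc(F)c(Cl)c3)c2cc1NC(=O)/C=C/c1ccccc1[N+](=O)[O-]`, which differs from the others at two places, gives 36500 nM in this assay. Compound 2 thus sits second highest of the three numbers, but all three lie within the scatter of one another, so no order can be drawn among them. Among the compounds with values here, the one single-point step, a 1.1-fold higher number from compound 1 to compound 2 (0.03 log units; within the scatter), shows that exchanging the aryl substitution pattern left the readout essentially unchanged.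

Compound 4 `COc1ccc(/C=C/C(=O)Nc2cc3c(Nc4ccc(F)c(Cl)c4)ncnc3cc2O[C@H]2CCOC2)cc1` is not yet measured. It differs from compound 2 as follows: methoxy in place of bromo on an aromatic carbon. Within the data shown here, no measured step exchanges a halogen for methoxy on this ring; the only step that bears on it, a 1.1-fold higher number from compound 1 to compound 2 (0.03 log units; within the scatter), was within the scatter, and compound 3 also falls close, so the present data give no sign that the aryl substituent moves the number. The expected step is therefore none beyond the scatter, a 1.0-fold lower number from compound 2 to compound 4 (0.01 log units; within the scatter). Compound 4 is estimated at 32000 nM, with a range from 14000 nM to 70000 nM.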

Compound 4, half-maximal inhibitory concentration: 5070 nM
The estimate for compound 4 lay 6.3-fold (0.80 log units) above the measured number; measured number outside the range, below it.
By their numbers in this assay, from the lowest: compound 4; then compounds 1, 2 and 3 (each within the scatter of the next).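

In this assay, within the data shown here, the aryl group on the double-bonded chain is no longer silent: methoxy in place of bromo on the aromatic carbon, para to a large group, gives a 6.4-fold lower number from compound 2 to compound 4 (0.81 log units; beyond the scatter) and is the first change to exceed the scatter. The 4-methoxyphenyl also separates from the 2,3-dichlorophenyl with a 5.9-fold lower number from compound 1 to compound 4 (0.77 log units; beyond the scatter) whereas the 4-bromophenyl and 2,3-dichlorophenyl stay together with a 1.1-fold higher number from compound 1 to compound 2 (0.03 log units; within the scatter) so, among compound 1, compound 2 and compound 4, only the methoxy-bearing aryl group departs from the others. No evidence at hand accounts for this step.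

As far as these compounds go, whether the lower number is specific to methoxy or extends to other groups on this aromatic carbon remains open; an amine, a hydroxyl or a longer ether chain such as ethoxy would test that. Also open, from the compounds shown here alone, is whether methoxy keeps this effect at other carbons of the ring, and whether a second methoxy on the same ring adds to the step or leaves the number where compound 4 puts it.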